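Stereochemical variant of a fused-ring benzyl ether

The compounds below may be only part of what the source reports. "The series", "measured", "known", "first", "only" and "open" are said of these compounds alone.

Measured compounds:
- compound 1 `c1ccc(COC[C@H]2O[C@H]3C[C@H]3[C@@H](OCc3ccccc3)[C@@H]2OCc2ccccc2)cc1` — a functional assay on HL-60 cells (Homo sapiens) for antiproliferative activity, read by MTT assay; on this read-out lower numbers stand for stronger inhibition and higher numbers for weaker inhibition: "not active" (no number reported)
- compound 2 `CC(C)C[C@@H]1O[C@H](COCc2ccccc2)[C@@H](OCc2ccccc2)[C@H](OCc2ccccc2)[C@H]1O` — this assay: 8500 nM
- compound 3 `CCCCCCCCCCCCCCCOC[C@H]1O[C@H](CCC)[C@H](O)[C@@H](OCCCCCCCCCCCCCCC)[C@@H]1OCCCCCCCCCCCCCCC` — this assay: "not active" (no number reported)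

Among the measured compounds shown here, compound 1 stands without a single number in this assay, as does compound 3; only compound 2 gives a numerical value, and nothing in the set connects compound 2 to compound 1 by a single change, so no step between measured compounds can be read.

Compound 4 `c1ccc(COC[C@H]2O[C@@H]3C[C@@H]3[C@@H](OCc3ccccc3)[C@@H]2OCc2ccccc2)cc1` has not been measured. It differs from compound 1 as follows: the two compounds have the same atoms and bonds and differ only in configuration as drawn: 2 of 5 stereo elements differ; a stereocentre at a saturated ring carbon is drawn S in compound 1 and R in compound 4; a stereocentre at a saturated ring carbon is drawn R in compound 1 and S in compound 4. The benzyl ether groups and the fused ring are retained.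

For the measured compounds named here, with compound 1 reported as "not active" (no number reported) and no measured step on which to size the effect of inverted configuration, the expectation for compound 4 is weak activity, most likely again outside the reportable range, with an even chance of no number at all. If a number is obtained, compound 4 is estimated at 25000 nM, within 6000 nM to 100000 nM.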

Compound 4, half-maximal inhibitory concentration: 38500 nM
The estimate for compound 4 lay 1.5-fold (0.19 log units) below the measured number; low and high end bracket the measured number.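

In this assay compound 1 gives "not active" (no number reported) and compound 4 gives 38500 nM, so no step can be read between them. Going by these compounds, the size of any effect of inverting the two ring stereocentres on antiproliferative activity remains open.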